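A few compounds are considered here, and "the series" means these few. Any claim that something is new, unique, unknown or untested is made for them only; others in the source may bear on it.

Measured compounds in an assay on HEK293 cells for activation of Kir3.1/Kir3.2 (Homo sapiens), read by thallium flux; on this read-out higher numbers stand for an effect only at larger amounts of compound and lower numbers for an effect already at smaller amounts:
compound 1 `Cc1cc(NC(=O)Cn2nnc(-c3ccccc3)n2)n(C2CCCCC2)n1`: 96 nM
compound 3 `Cc1cc(NC(=O)Cn2nnc(-c3ccccc3)n2)n(C2CCCC2)n1`: 163 nM
compound 2 `Cc1cc(NC(=O)Cn2nnc(-c3ccccc3)n2)n(C2CCC(C)(C)CC2)n1`: the assay gives only a limit, > 221 nM

Compound 1 has the lowest of the two numbers, and its nearest neighbour is compound 3 (a 1.7-fold higher number from compound 1 to compound 3 (0.23 log units; within the scatter)), so the two cannot be told apart. Compound 4 `CC1CC1c1cc(NC(=O)Cn2nnc(-c3ccccc3)n2)n(C2CCCCC2)n1` differs from compound 1 by 2-methylcyclopropyl in place of methyl on an aromatic carbon. Among the measured compounds shown here, the measured steps, an at least 2.3-fold higher number from compound 1 to compound 2 (0.36 log units; beyond the scatter) and a 1.7-fold higher number from compound 1 to compound 3 (0.23 log units; within the scatter), all change the group on the aromatic nitrogen, not the aromatic carbon, so none of them bears directly on this change; the data show only that the shared core tolerates small changes of that kind with little movement. Compound 4 is therefore expected to give about 150 nM, between 50 nM and 500 nM, an expected step of a 1.6-fold higher number from compound 1 to compound 4 (0.19 log units; within the scatter).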

Compound 4, half-maximal effective concentration: 843 nM
For compound 4 the middle estimate is 5.6-fold (0.75 log units) below the measured one; the measured number lies above the stated range.
By their numbers in this assay, from the lowest: compounds 1 and 3 (each within the scatter of the next); then compound 4.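

Among the compounds shown here, the aromatic carbon next to the ring nitrogen does not tolerate every change in this assay: with 2-methylcyclopropyl in place of methyl there is an 8.8-fold higher number from compound 1 to compound 4 (0.94 log units; beyond the scatter), whereas the earlier steps changed only the group on the aromatic nitrogen. Nothing measured here accounts for this step. The compounds shown leave open whether ethyl, cyclopropyl without its methyl, or a chain ending in an amine would give a different number at this carbon. They also leave open whether the step would be the same with cyclopentyl on the aromatic nitrogen.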